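This account rests on a few compounds, and the source may have more. Where it says the series, first, only, none or still open, it means among the compounds named here.

Among the compounds with values here, compound 3 `CCCCCCCC(=O)c1c(OC)c(Cl)c(OC)c(Cl)c1OC` gives 15300 nM in a functional assay on the whole organism (S2 cells, strain S2) for inhibition, with Drosophila as the target, read by a luciferase reporter, with stated times of 1.5 h and 8 h (on this read-out higher numbers stand for weaker inhibition and lower numbers for stronger inhibition), the highest of the three numbers so far; its gap to compound 2 `CCCCCC(=O)c1c(O)c(Cl)c(O)c(Cl)c1O`, which gives 9900 nM, is within the scatter, while its gap to compound 1 `CCCCCC(=O)c1c(O)c(Cl)c(OC)c(Cl)c1O`, which gives 4600 nM, is beyond the scatter. Within the data shown here, the only measured single-point step, a 2.2-fold higher number from compound 1 to compound 2 (0.33 log units; beyond the scatter), concerns an oxygen on the ring and does not touch the chain. Compound 4 `CCCC(=O)c1c(OC)c(Cl)c(OC)c(Cl)c1OC` differs from compound 3 by hydrogen in place of butyl on a saturated chain carbon, three bonds along the chain from a carbonyl carbon. Among the measured compounds shown here, no measured pair varies the chain on the shared core, so no step size can be taken from the data, and the change is assumed to stay within the scatter, with wide uncertainty. Compound 4 is therefore expected to give about 18000 nM in this assay, within 6000 nM to 55000 nM. The expected step is a 1.2-fold higher number from compound 3 to compound 4 (0.07 log units; within the scatter).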

Compound 4, half-maximal inhibitory concentration: 20800 nM
Estimate against measurement, compound 4: 1.2-fold (0.06 log units) below; low and high end bracket the measured number.
By their numbers in this assay, from the lowest: compound 1; then compounds 2, 3 and 4 (each within the scatter of the next, the first and the last beyond it).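

Hydrogen in place of butyl, on a saturated chain carbon three bonds along the chain from a carbonyl carbon, gives a 1.4-fold higher number from compound 3 to compound 4 (0.13 log units; within the scatter) in this assay. Within the data shown here, this is the first measured step on the chain, and on the shared core of these two compounds the two chain lengths are not told apart. Nothing measured here offers an explanation for this result.

As far as these compounds go, whether a longer chain or a terminal amine would move the number stays open. So does whether the chain step would read the same on the core of compound 1.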